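Phenylsulfanyl Swapped for Methylsulfinyl: Weaker Inhibition Expected

A few compounds are considered here, and "the series" means these few. Any claim that something is new, unique, unknown or untested is made for them only; others in the source may bear on it.

Compound 3 `CNC1=C(Sc2ccccc2)C(=O)c2cccnc2C1=O` is tested in a functional assay on cells (Neutrophil, Homo sapiens) for inhibition, read by WST assay, with a stated time of 20 min (on this read-out higher numbers stand for weaker inhibition and lower numbers for stronger inhibition), where it gives 92800 nM. Among the plain numbers in hand that is the highest: compound 1 `CNC1=C(Cl)C(=O)c2cccnc2C1=O` gives 41100 nM, and the step of a 2.3-fold higher number from compound 1 to compound 3 (0.35 log units; beyond the scatter) lies beyond the usual scatter. Compound 2 `CNC1=C(SC)C(=O)c2cccnc2C1=O` reaches only a limit of the assay, > 200000 nM, and that is not a number. Compound 4 `CNC1=C([S+](C)[O-])C(=O)c2cccnc2C1=O` differs from compound 3 in one place: a group of 3 heavy atoms (1 carbon, 1 oxygen, 1 sulfur; no ring) in place of a group of 7 heavy atoms (6 carbon, 1 sulfur; one six-membered aromatic ring of carbon only), on a double-bonded ring carbon. Among the compounds with values here, two measured steps bear on this change. Putting a phenyl in place of a methyl on the sulfur gave an at least 2.1-fold lower number from compound 2 to compound 3 (0.33 log units; beyond the scatter), so taking the phenyl away again should push the number up. Putting methylsulfanyl in place of chloro gave an at least 4.8-fold higher number from compound 1 to compound 2 (0.68 log units; beyond the scatter), which also points to a high number for a small sulfur group at this place, as the limit of > 200000 nM in this assay, at which 1 of the 3 values shown sits, shows. Compound 4 is therefore expected to inhibit more weakly than compound 3, the expected step being a 2.2-fold higher number from compound 3 to compound 4 (0.33 log units; beyond the scatter). The estimate for compound 4 is 200000 nM, with a range from 80000 nM to 450000 nM, and the assay may well report only a limit.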

Compound 4, half-maximal inhibitory concentration: > 200000 nM
Compound 4: only a limit was reported; the forecaster's own chance of this, stated with the estimate: 55%; the middle value lies on the limit itself.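

Replacing phenylsulfanyl with methylsulfinyl in this assay gives an at least 2.1-fold higher number from compound 3 to compound 4 (0.33 log units; beyond the scatter), and methylsulfinyl in place of chloro gives an at least 4.8-fold higher number from compound 1 to compound 4 (0.68 log units; beyond the scatter); both steps rest on a limit of the assay for compound 4, not on a number. With compound 4, a second small sulfur group on this double-bonded ring carbon ends at the top of the measurable range, as compound 2 did: the limit of > 200000 nM in this assay, at which 2 of the 4 values shown sit. Compound 2 and compound 4 both stop at limits, so the step between them cannot be read, and the effect of the oxygen on the sulfur stays hidden.

From the compounds shown here alone, how much weaker compound 4 truly is remains open. Also open, going by these compounds, is whether an amine, a carboxylic acid or a longer chain on the sulfur at this place would give a lower number than chloro does.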